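From dimethylamino to methoxy on the shared core

The source may hold more compounds than are shown below. What is called first, only, known or untested is meant among the compounds shown, and "the series" means these compounds.

Measured in an ADME assay on HPC cells (Homo sapiens) for cytotoxicity, with a stated time of 24 h; a lower number here means that less compound is tolerated, a higher number that more compound is tolerated:
- Compound 1 `O=C1/C(=C/c2ccccc2)CCC/C1=C\c1ccccc1[N+](=O)[O-]` gives 16000 nM as a number
- Compound 2 `CN(C)c1ccc(/C=C2\CCC/C(=C\c3ccccc3[N+](=O)[O-])C2=O)cc1` gives > 400000 nM as a limit of the assay

Compound 2 stands at the limit of > 400000 nM in this assay, at which 1 of the 2 values shown sits, and so has no number of its own. Compound 3 `COc1ccc(/C=C2\CCC/C(=C\c3ccccc3[N+](=O)[O-])C2=O)cc1` carries methoxy in place of dimethylamino on an aromatic carbon. Going by the values given here, only one measured step bears on this change, and it is large: an at least 25-fold higher number from compound 1 to compound 2 (1.39 log units; beyond the scatter) came with dimethylamino in place of hydrogen on an aromatic carbon. Compound 3 gives up the dimethylamino group that marks an at least 25-fold higher number from compound 1 to compound 2 (1.39 log units; beyond the scatter) and so is expected to move back toward compound 1, although the limit on compound 2 leaves the size of the step loose. The expected move, large and toward a lower number, is an at least 8.0-fold lower number from compound 2 to compound 3 (0.90 log units; beyond the scatter) in this assay as estimated here. The expected value for compound 3 is 50000 nM (12000 nM to 200000 nM).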

Compound 3, half-maximal cytotoxic concentration: > 400000 nM
Compound 3: only a limit was reported; the forecaster's own chance of this, stated with the estimate: 15%; at least 8.0-fold (0.90 log units) between middle value and limit.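

In this assay, the large rise over compound 1 turns out not to belong to dimethylamino alone: methoxy on the same aromatic carbon came with an at least 25-fold higher number from compound 1 to compound 3 (1.39 log units; beyond the scatter). Two different groups at this place now part from compound 1 in the same direction, so replacing the hydrogen there matters more than which of these two groups enters. The step between compound 2 and compound 3 cannot be read, since each compound stands at a limit and not at a number: the limit of > 400000 nM in this assay, at which 2 of the 3 values shown sit.

Going by these compounds, how far apart compound 2 and compound 3 truly lie remains open. On these data alone, it is also open whether a methyl group, a chlorine atom or a carboxylic acid on this aromatic carbon would bring the same rise.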